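The source may hold more compounds than are shown below. What is called first, only, known or untested is meant among the compounds shown, and "the series" means these compounds.

Series notes. In an ADME assay on the whole organism (strain Sprague-Dawley) for pharmacokinetics, with Rattus norvegicus as the target (on this read-out higher numbers stand for fast clearance and lower numbers for slow clearance), compound 1 `Nc1nc(Nc2ccc(N3CCN(C4CC5CCC4C5)CC3)cc2)nn1-c1nccc2ccccc12` gives 52 mL/min/kg. Compound 2 `COc1cc2ncnc(-n3nc(Nc4ccc(N5CCN(C6CC7CCC6C7)CC5)c(Cl)c4)nc3N)c2cc1OC` gives 117 mL/min/kg in this assay. Within the data shown here, compound 1 thus stands at the lowest of the two numbers measured so far; its gap to compound 2 lies beyond the usual scatter, but these two compounds differ in more than one place, so the gap says only what the two values themselves show. Compound 3 `Nc1nc(Nc2ccc(N3CCN(C4CC5CCC4C5)CC3)cc2)nn1-c1ncnc2ccc(F)cc12` is the next member to be run in this assay. Its structural change from compound 1 is 6-fluoroquinazolin-4-yl in place of isoquinolin-1-yl on an aromatic nitrogen. Among the measured compounds shown here, no single-site step between measured compounds is available to calibrate a change of this kind, so its direction is open. The remainder of compound 1 is carried over unaltered, and the expected step of a 1.2-fold higher number from compound 1 to compound 3 (0.06 log units; within the scatter) is therefore taken as none beyond the scatter, with a modest rise held possible. On that basis compound 3 is estimated at 60 mL/min/kg in this assay, within a range from 30 mL/min/kg to 120 mL/min/kg.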

Compound 3, clearance: 44 mL/min/kg
Compound 3: middle estimate off by 1.4-fold (0.13 log units), on the high side; low and high end bracket the measured number.
By their numbers in this assay, from the lowest: compounds 3 and 1 (each within the scatter of the next); then compound 2.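

In this assay, among these compounds, 6-fluoroquinazolin-4-yl in place of isoquinolin-1-yl on the aromatic nitrogen gives a 1.2-fold lower number from compound 1 to compound 3 (0.07 log units; within the scatter), and this is the first single-site step available. It shows that at this position, on a five-membered aromatic ring with 3 nitrogen, the swap of one ring carbon for a second ring nitrogen, together with the entry of a fluorine, leaves the clearance read-out within the usual scatter, so the rest of compound 1 can carry either group without a readable difference. Among the compounds shown here, nothing measured so far connects this outcome with any property of either group.

For the compounds shown here, the nitrogen and the fluorine enter together, so the single step cannot separate what each contributes, and a plain quinazolin-4-yl or a 6-chloroquinazolin-4-yl would be needed to pull the two apart. On these data alone, it also remains open whether clearance stays this flat at the same position with a group of a different kind, such as a simple phenyl, a pyridine carrying an amine or a ring carrying a carboxylic acid, and compound 2, which differs from compound 3 in more than one place, cannot settle this.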